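A few compounds are considered here, and "the series" means these few. Any claim that something is new, unique, unknown or untested is made for them only; others in the source may bear on it.

Three compounds share one core and differ only in the group on the amine nitrogen of the piperazine ring. Compound 3 `CCCc1nc(-c2ccccc2)c(CNCCCN2CCN(c3ccccc3)CC2)o1` carries a plain phenyl there, and in an assay on HEK293 cells for inhibition of Voltage-dependent T-type calcium channel subunit alpha-1G (Homo sapiens), read by fluorescence, tested at 10 uM (a lower number here means less inhibition, a higher number more inhibition at the concentration tested (going by the name of the read-out)), compound 3 gives 43.7%, the lowest of the three numbers. Compound 1 `CCCc1nc(-c2ccccc2)c(CNCCCN2CCN(c3ccc(F)cc3)CC2)o1`, with a 4-fluorophenyl, gives 62.5% in this assay, and compound 2 `CCCc1nc(-c2ccccc2)c(CNCCCN2CCN(c3cccc(Cl)c3)CC2)o1`, with a 3-chlorophenyl, gives 65.9%. Both halogenated compounds stand clear of compound 3: the step of a number 18.8 percentage points lower from compound 1 to compound 3 (beyond the scatter) and the step of a number 22.2 percentage points lower from compound 2 to compound 3 (beyond the scatter) both run beyond the scatter, while the step of a number 3.4 percentage points higher from compound 1 to compound 2 (within the scatter) stays within it. So far, then, a halogen on that phenyl has gone with a modest gain whatever its position, and the bare ring has been the weaker case.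

Compound 4 `CCCc1nc(-c2ccccc2)c(CNCCCN2CCN(c3ccccc3F)CC2)o1` is the next step from compound 3: fluoro in place of hydrogen on an aromatic carbon, so that the phenyl becomes a 2-fluorophenyl. Going by the values given here, the closest precedent is the reverse of the step from compound 1 to compound 3, a fluoro entering an otherwise identical ring, and the chloro case in compound 2 points the same way. A rise of roughly that size, a number 14.3 percentage points higher from compound 3 to compound 4 (beyond the scatter), is therefore expected in this assay, and compound 4 is estimated at 58%, in the range 42% to 72%.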

Compound 4, a percentage reported as inhibition, at one concentration (the size of the read-out at that concentration, not a potency): 54.4%
The estimate for compound 4 lay 3.6 percentage points above the measured number, within the range that was stated.
By their numbers in this assay, from the lowest: compound 3; then compounds 4, 1 and 2 (each within the scatter of the next, the first and the last beyond it).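

The gain from a halogen now extends to a third case: fluoro on an aromatic carbon ortho to a large group still separates from the bare phenyl in this assay, with a number 10.7 percentage points higher from compound 3 to compound 4 (beyond the scatter). Moving the fluoro makes no readable difference between these two placements, as a number 8.1 percentage points lower from compound 1 to compound 4 (within the scatter) stays inside the usual spread of repeats, so the 2-fluorophenyl and 4-fluorophenyl compounds cannot be ranked. The halogenated compounds are no longer all alike, however, since a number 11.5 percentage points lower from compound 2 to compound 4 (beyond the scatter) sets the 3-chlorophenyl compound apart from the 2-fluorophenyl one, although that step changes both the halogen and its place, so neither change alone can be credited with it.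

Nothing available here accounts for these differences in the numbers. Whether fluoro and chloro differ at one and the same place stays open, since no pair shown changes the halogen alone, and so does how a methoxy group, a trifluoromethyl group or an amine on this phenyl would compare with the halogens.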